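A few compounds are considered here, and "the series" means these few. Any claim that something is new, unique, unknown or untested is made for them only; others in the source may bear on it.

Measured in a functional assay on MIA PaCa-2 cells (Homo sapiens) for antiproliferative activity; on this read-out lower numbers stand for an effect already at smaller amounts and higher numbers for an effect only at larger amounts of compound:
Compound 1 `Cc1cc2c(C(N)=O)cccc2n1-c1nc2c(c(NCc3ccccc3)n1)CCCC2`: 128 nM
Compound 2 `Cc1cc2c(C(=O)NCCC#N)cccc2n1-c1nc2c(c(NCc3ccccc3)n1)CCCC2`: 517 nM
Compound 3 `CCC#CC(=O)Nc1cccc2c1cc(C)n2-c1nc2c(c(NCc3ccccc3)n1)CCCC2`: 463 nM
Compound 4 `CCC(=O)Nc1cccc2c1cc(C)n2-c1nc2c(c(NCc3ccccc3)n1)CCCC2`: not yet measured

Compound 3 gives 463 nM, the middle of the three numbers, yet it cannot be separated from its nearest neighbour: a 1.1-fold lower number from compound 2 to compound 3 (0.05 log units; within the scatter). Its gap to the lowest number is larger: a 3.6-fold higher number from compound 1 to compound 3 (0.56 log units; beyond the scatter). The remaining step is similar: a 4.0-fold higher number from compound 1 to compound 2 (0.61 log units; beyond the scatter). Compound 4 differs from compound 3 in one group: ethyl in place of but-1-yn-1-yl on a carbonyl carbon. Within the data shown here, no measured step makes this exact change. The measured steps that come closest are modest at most, so no step beyond the scatter is expected in this assay. The expected step is a 1.2-fold lower number from compound 3 to compound 4 (0.06 log units; within the scatter). Compound 4 is estimated at 400 nM, with an expected range of 160 nM to 1000 nM.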

Compound 4, half-maximal effective concentration: 1010 nM
Beside the measured number, compound 4's estimate is 2.5-fold (0.40 log units) below it; measured number above the stated range.
By their numbers in this assay, from the lowest: compound 1; then compounds 3, 2 and 4 (each within the scatter of the next, the first and the last beyond it).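

In this assay, ethyl in place of but-1-yn-1-yl on a carbonyl carbon gives a step beyond the scatter (a 2.2-fold higher number from compound 3 to compound 4 (0.34 log units; beyond the scatter)), so this place responds to a change in the group on the carbonyl carbon alone. Propanoylamino in place of (2-cyanoethyl)carbamoyl stays within the scatter (a 2.0-fold higher number from compound 2 to compound 4 (0.29 log units; within the scatter)), whereas propanoylamino in place of carbamoyl gives the largest step among these compounds (a 7.9-fold higher number from compound 1 to compound 4 (0.90 log units; beyond the scatter)). Nothing measured alongside these compounds accounts for the steps. As far as these compounds go, the step changes chain length and removes the triple bond together, so their shares stay open. From the compounds shown here alone, whether butyl on the carbonyl carbon would fall nearer compound 3 or compound 4 also stays open.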